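From 4-hydroxyphenyl to 3-hydroxyphenyl on compound 3

The compounds below may be only part of what the source reports. "The series", "measured", "known", "first", "only" and "open" are said of these compounds alone.

Three related compounds have been tested in a functional assay on A549 cells (Homo sapiens) for antiproliferative activity, with a stated time of 72 h; on this read-out higher numbers stand for weaker inhibition and lower numbers for stronger inhibition. Compound 1 `COc1ccc(OC)c(Nc2nc(/C=C/c3ccccc3OC(C)=O)nc3ccccc23)c1` gave no number, only a limit of the assay, > 25000 nM. Compound 2 `COc1ccccc1/C=C/c1nc(Nc2ccccc2Cl)c2ccccc2n1` also reached only a limit, > 25000 nM. Compound 3 `COc1ccccc1/C=C/c1nc(Nc2ccc(O)cc2)c2ccccc2n1` is the only one of the three with an actual number, 13000 nM.

Compound 4 `COc1ccccc1/C=C/c1nc(Nc2cccc(O)c2)c2ccccc2n1` has the same atoms as compound 3, joined differently: 3-hydroxyphenyl in place of 4-hydroxyphenyl on a nitrogen on an aromatic ring. The group that changes keeps its size and its counted features, and only the place of attachment differs.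

For the measured compounds named here, one measured step bears on this change, and only indirectly. It is an at least 1.9-fold lower number from compound 2 to compound 3 (0.28 log units; that floor lies within the scatter), where 4-hydroxyphenyl replaces 2-chlorophenyl at the same nitrogen. That step involves a different pair of groups, and its floor does not clear the scatter, so it offers no firm size or direction for the new change. With so little to go on, the sensible expectation is no shift beyond the scatter. The expected step is a 1.1-fold higher number from compound 3 to compound 4 (0.03 log units; within the scatter). For compound 4 the estimated value is 14000 nM, with an expected range from 6000 nM to 25000 nM.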

Compound 4, half-maximal inhibitory concentration: 16600 nM
Compound 4: the middle estimate sits 1.2-fold (0.07 log units) below what was measured; the measured number falls inside the stated range.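

Putting 3-hydroxyphenyl in place of 4-hydroxyphenyl on the nitrogen gives a 1.3-fold higher number from compound 3 to compound 4 (0.11 log units; within the scatter) in this assay, so this pair gives no sign that the two placings of the hydroxyl group can be told apart on this read-out. The comparison with the 2-chlorophenyl compound now reads an at least 1.5-fold lower number from compound 2 to compound 4 (0.17 log units; that floor lies within the scatter), and, like the earlier step from that compound, this floor does not clear the scatter. The step gives only a floor, not a true size, because compound 2 sits at a limit of the assay rather than at a real number: the limit of > 25000 nM in this assay, at which 2 of the 4 values shown sit.

Going by these compounds, what stays open is whether the hydroxyl group contributes anything at all, which a plain phenyl on the same nitrogen, or a phenyl carrying an amine or a carboxylic acid in its place, would help to show. On these data alone, it is also open whether the lack of a clear difference between these two hydroxyphenyl groups would hold if the rest of the molecule were changed.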